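Shifting the anilino ring from trifluoromethyl to chloro-fluoro

The compounds below may be only part of what the source reports. "The series", "measured", "known", "first", "only" and "open" are said of these compounds alone.

In a functional assay on NCI-H1975 cells (Homo sapiens) for antiproliferative activity, read by MTT assay, with a stated time of 72 h (a lower number here means a stronger inhibitor, a higher number a weaker inhibitor), compound 1 `NS(=O)(=O)c1ccc(NC(=S)Nc2ccc3ncnc(Nc4cccc(C(F)(F)F)c4)c3c2)cc1` gives 7590 nM, and compound 2 `NS(=O)(=O)c1ccc(NC(=S)Nc2ccc3ncnc(Nc4ccc(C(F)(F)F)cc4)c3c2)cc1` gives 17100 nM, which is the higher of the two numbers. Going by the values given here, the only step within this set is a 2.3-fold higher number from compound 1 to compound 2 (0.35 log units; beyond the scatter). Compound 3 `NS(=O)(=O)c1ccc(NC(=S)Nc2ccc3ncnc(Nc4cccc(Cl)c4F)c3c2)cc1` differs from compound 2 in that (3-chloro-2-fluorophenyl in place of 4-(trifluoromethyl)phenyl on a nitrogen on an aromatic ring). That step alone does not fix the direction, yet it shows the aryl substitution pattern moving the number modestly, so a modest step in this assay is expected, with a lower number expected for compound 3 as a 2.9-fold lower number from compound 2 to compound 3 (0.45 log units; beyond the scatter). Compound 3 is therefore estimated at 6000 nM, within a range from 1800 nM to 20000 nM.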

Compound 3, half-maximal inhibitory concentration: 25100 nM
Compound 3: middle estimate off by 4.2-fold (0.62 log units), on the low side; the whole stated range lies below it.
By their numbers in this assay, from the lowest: compound 1; then compounds 2 and 3 (each within the scatter of the next).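

In this assay, replacing 4-(trifluoromethyl)phenyl with 3-chloro-2-fluorophenyl on this nitrogen leaves the two compounds indistinguishable, at a 1.5-fold higher number from compound 2 to compound 3 (0.17 log units; within the scatter). Measured against 3-(trifluoromethyl)phenyl, the same group gives a 3.3-fold higher number from compound 1 to compound 3 (0.52 log units; beyond the scatter), so compound 1 keeps the lowest number of the three, and a halogen pair offers no route past it here. Nothing available bears on why these numbers fall as they do. Still open, going by these compounds, is how this ring would read carrying a methoxy group or an amine in place of these halogens and trifluoromethyl.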